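Swapping the acyl group on a nitroanilide core

The source may report more compounds than this note shows. Statements on the series, on what has been measured and on what is new or still open speak of the compounds shown alone.

Compound 1 `O=C(OC1(C(=O)Nc2ccc([N+](=O)[O-])cc2)CCCCC1)c1ccc(Br)cc1` carries a 4-bromophenyl group on a carbonyl carbon of the shared core. In a functional assay on NFS-60 cells (Mus musculus) for inhibition, read by MTT assay, with a stated time of 72 h (on this read-out higher numbers stand for weaker inhibition and lower numbers for stronger inhibition), compound 1 gives 236 nM, the lowest number among the three compounds measured here. Compound 2 `CCOC(=O)c1ccccc1C(=O)OC1(C(=O)Nc2ccc([N+](=O)[O-])cc2)CCCCC1` gives 488 nM, and compound 3 `CC(=O)OC1(C(=O)Nc2ccc([N+](=O)[O-])cc2)CCCCC1` gives 517 nM; both sit beyond the usual scatter away from compound 1, so compound 1 counts as the strongest inhibitor of the three.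

Compound 4 `CCC(=O)OC1(C(=O)Nc2ccc([N+](=O)[O-])cc2)CCCCC1` has not yet been measured. It differs from compound 1 in one place: ethyl in place of 4-bromophenyl on a carbonyl carbon. Going by the values given here, the only measured step that bears directly on this change is the one from compound 1 to compound 3, where a methyl group replaces the same 4-bromophenyl group and the number rises by a 2.2-fold higher number from compound 1 to compound 3 (0.34 log units; beyond the scatter). Ethyl is one carbon longer than methyl, so a step of a similar size and in the same direction is expected for compound 4 in this assay. The step from compound 1 to compound 4 is therefore estimated at a 1.9-fold higher number from compound 1 to compound 4 (0.28 log units; within the scatter). Compound 4 is expected to give about 450 nM, with a plausible range from 220 nM to 900 nM.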

Compound 4, half-maximal inhibitory concentration: 6.4 nM
Beside the measured number, compound 4's estimate is 70-fold (1.85 log units) above it; measured number below the stated range.
By their numbers in this assay, from the lowest: compound 4; then compound 1; then compounds 2 and 3 (each within the scatter of the next).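

In this assay, going by these compounds alone, the position on this carbonyl carbon proves far more sensitive than the earlier compounds suggested: ethyl in place of 4-bromophenyl gives a 37-fold lower number from compound 1 to compound 4 (1.57 log units; beyond the scatter), whereas methyl in the same place gave only a 2.2-fold higher number from compound 1 to compound 3 (0.34 log units; beyond the scatter), in the opposite direction. The sharpest contrast comes from one added carbon, as methyl in place of hydrogen on the saturated chain carbon bound to the carbonyl carbon gives an 81-fold lower number from compound 3 to compound 4 (1.91 log units; beyond the scatter), so the numbers do not follow the count of atoms in the group: the ethyl and methyl compounds lie on either side of the 4-bromophenyl compound. Nothing available here explains why this one carbon matters so much.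

Whether ethyl is a narrow optimum or the first step of a continuing trend stays open, since the compounds shown stop short of a propyl or butyl chain and of a branched group such as isopropyl. It is also unknown how the position would respond to an amine or a carboxylic acid at the end of such a chain.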